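Pyrimidinyl for phenyl on the piperazine triazene: expected cytotoxicity

A few compounds are considered here, and "the series" means these few. Any claim that something is new, unique, unknown or untested is made for them only; others in the source may bear on it.

Measured so far:
- Compound 1, `c1ccc(/N=N/N2CCCC2)cc1`: > 100000 nM
- Compound 2, `CN(C)CCCN(/N=N/c1ccccc1)c1cccc(C(F)(F)F)c1`: 20000 nM
- Compound 3, `c1ccc(/N=N/N2CCN(c3ccccc3)CC2)cc1`: >= 100000 nM

In an ADME assay on Vero cells (Chlorocebus sabaeus) for cytotoxicity, read by crystal violet staining (on this read-out lower numbers stand for higher toxicity in this test and higher numbers for lower toxicity in this test), compound 3 gives >= 100000 nM, which is a limit of the assay and not a number. Compound 1 also stands at a limit, (the limit of > 100000 nM in this assay, at which 1 of the 3 values shown sits). Among the measured compounds shown here, compound 2 is the only one with a measured number, 20000 nM.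

Compound 4, `c1ccc(/N=N/N2CCN(c3ncccn3)CC2)cc1`, differs from compound 3 by pyrimidin-2-yl in place of phenyl on an amine nitrogen in a ring. For the measured compounds named here, no measured step of this kind exists among the three compounds, so no size can be read from them. The step from compound 3 to compound 4 is expected to be none beyond the scatter, a number no higher from compound 3 to compound 4 (the limit leaves the size open). Compound 4 is therefore estimated at 100000 nM, between 50000 nM and 200000 nM, most likely reported again as a limit.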

Compound 4, half-maximal cytotoxic concentration: 65000 nM
Compound 4: middle estimate off by 1.5-fold (0.19 log units), on the high side; low and high end bracket the measured number.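

Placing pyrimidin-2-yl in place of phenyl on an amine nitrogen in a ring gives, in this assay, an at least 1.5-fold lower number from compound 3 to compound 4 (0.18 log units; that floor lies within the scatter). This position now carries a real number, so the two ring nitrogens of pyrimidin-2-yl are compatible with a measurable reading in this test. Compound 3 stands at a limit, so the true size of the step stays open: the limit of >= 100000 nM in this assay, at which 1 of the 4 values shown sits.

From the compounds shown here alone, it remains open whether one ring nitrogen would give the same reading, as in pyridin-2-yl. Going by these compounds, it is also open how a non-aromatic group at this place, such as an acetyl or a longer amine chain, would read.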